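Sulfonyl amine variation on the shared core: next step

The source may report more compounds than this note shows. Statements on the series, on what has been measured and on what is new or still open speak of the compounds shown alone.

Two measured compounds share a core that carries a sulfonyl group on a saturated chain carbon, differing only in the amine on that sulfonyl sulfur. Compound 1 `CCNS(=O)(=O)Cc1noc2ccc(F)cc12` was tested in a functional assay on the whole organism (strain STD-dd) with Mus musculus as the target, in the maximal electroshock model, with a stated time of 2 h; on this read-out lower numbers stand for an effect already at smaller amounts and higher numbers for an effect only at larger amounts of compound; in this read-out compound 1 gives 32 mg/kg. Compound 2 `CN(C)S(=O)(=O)Cc1noc2ccc(F)cc12` carries dimethylamino in place of ethylamino on a sulfonyl sulfur, and in this assay compound 2 gives 32 mg/kg. The step of no change at the digits printed from compound 1 to compound 2 (within the scatter) is flat, so compound 2 stands level with compound 1 at the digits shown, within the scatter.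

Compound 3 `CN1CCN(S(=O)(=O)Cc2noc3ccc(F)cc23)CC1` is not yet measured. It differs from compound 2 by 4-methylpiperazin-1-yl in place of dimethylamino on a sulfonyl sulfur. Among the measured compounds shown here, the only measured step at this position, no change at the digits printed from compound 1 to compound 2 (within the scatter), bears on the change and showed no movement beyond the scatter. A 4-methylpiperazin-1-yl group, with its one six-membered non-aromatic ring, lies outside the range of amines tried so far, so the expectation rests on a single flat step. The step of no change at the digits printed from compound 2 to compound 3 (within the scatter) is therefore expected to stay within the scatter, with no direction favoured. Compound 3 is estimated at 32 mg/kg, in the range 14 mg/kg to 80 mg/kg.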

Compound 3, dose for half-maximal effect: 100 mg/kg
The estimate for compound 3 lay 3.1-fold (0.49 log units) below the measured number; the measured number lies above the stated range.
By their numbers in this assay, from the lowest: compounds 1 and 2 (each within the scatter of the next); then compound 3.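

In this assay, the position on a sulfonyl sulfur proves able to respond to the amine: 4-methylpiperazin-1-yl in place of dimethylamino gives a 3.1-fold higher number from compound 2 to compound 3 (0.49 log units; beyond the scatter), and in place of ethylamino it gives a 3.1-fold higher number from compound 1 to compound 3 (0.49 log units; beyond the scatter). The flat no change at the digits printed from compound 1 to compound 2 (within the scatter) therefore holds only for the two amines without a ring and does not extend to this larger group, which brings one six-membered non-aromatic ring with 2 hetero atoms, 7 heavy atoms in place of 3 in the step from compound 2, and 1 hydrogen-bond acceptor. No measurement is available that would tie the higher number of compound 3 to any one of these differences.

Whether the ring itself or the second ring nitrogen with its methyl accounts for the step remains open, and piperidin-1-yl and morpholin-4-yl on the same sulfonyl sulfur would help separate the two. Going by these compounds, it is also open how a plain unsubstituted amino group or a longer open chain such as n-butylamino would compare with compounds 1 and 2 in this assay.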